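The source may hold more compounds than are shown below. What is called first, only, known or untested is meant among the compounds shown, and "the series" means these compounds.

Measured compounds:
Compound 1, `COc1cc(/C=C/c2c[nH]c3ccccc23)cc(OC)c1OC`: 3230 nM
Compound 2, `COc1cc(/C=C/c2cn(C)c3ccccc23)cc(OC)c1OC`: 3090 nM
Compound 3, `COc1cc(/C=C/c2ccc3[nH]ccc3c2)cc(OC)c1OC`: 380 nM

The three measured compounds were tested in a functional assay on HL-60 cells (Homo sapiens) for inhibition; on this read-out higher numbers stand for weaker inhibition and lower numbers for stronger inhibition. Compound 1, `COc1cc(/C=C/c2c[nH]c3ccccc23)cc(OC)c1OC`, gives 3230 nM in this assay. Compound 2, `COc1cc(/C=C/c2cn(C)c3ccccc23)cc(OC)c1OC`, differs from it by methyl in place of hydrogen on an aromatic nitrogen, and the resulting step, a 1.0-fold lower number from compound 1 to compound 2 (0.02 log units; within the scatter), is within the scatter, so the two values are treated as equal. Compound 3, `COc1cc(/C=C/c2ccc3[nH]ccc3c2)cc(OC)c1OC`, carries the same atoms joined differently; the difference between its core and that of compound 1 is not broken down here. In this assay compound 3 gives 380 nM, the lowest of the three numbers, and its steps to compound 1 and compound 2 are both beyond the scatter.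

Compound 4, `COc1cc(/C=C/c2ccc3c(ccn3C)c2)cc(OC)c1OC`, is not yet measured. It differs from compound 3 by methyl in place of hydrogen on an aromatic nitrogen. For the measured compounds named here, this is the same kind of change as the one from compound 1 to compound 2, though the place is not described in identical words: for the earlier pair the aromatic nitrogen sits two ring bonds from the ring atom that bears a large group, while for compound 3 and compound 4 no such note is given. Going by the values given here, the only precedent for this change is the pair compound 1 and compound 2, where the step was within the scatter. Because a 1.0-fold lower number from compound 1 to compound 2 (0.02 log units; within the scatter) shows no movement, the same kind of change on compound 3 is expected to leave the value largely where it is. The expected step is therefore a 1.1-fold higher number from compound 3 to compound 4 (0.02 log units; within the scatter). Compound 4 is estimated at 400 nM, in a range from 150 nM to 1200 nM.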

Compound 4, half-maximal inhibitory concentration: 27 nM
Compound 4: the middle estimate sits 15-fold (1.17 log units) above what was measured; the measured number lies below the stated range.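

In this assay, methyl in place of hydrogen on an aromatic nitrogen gives a large step on the core of compound 3 (a 14-fold lower number from compound 3 to compound 4 (1.15 log units; beyond the scatter)), and the same change does not carry over in size between the two cores: the same change on two cores in this assay, a 1.0-fold lower number (0.02 log units; within the scatter) from compound 1 to compound 2 and a 14-fold lower number (1.15 log units; beyond the scatter) from compound 3 to compound 4, 13-fold (1.13 log units) apart, beyond the scatter of two such steps
The effect of this change therefore depends on the core it is made on, and the flat step between compound 1 and compound 2 goes against any claim that this methyl strengthens inhibition throughout the series. For the compounds shown here, the four compounds do not show what in the two cores sets the steps apart, nor which of the two results a further core would follow, since they offer only two pairs, both read in this assay.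

The compounds shown leave open whether a longer chain such as ethyl or propyl, or a benzyl group, on the same aromatic nitrogen of the core of compound 3 would hold the low number of compound 4 or lose it. They also leave open how a chain ending in an amine or a carboxylic acid would fare at that place, and whether the large step seen with methyl is specific to that small group.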